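Swapping the Side Ring on a Shared Core

The compounds below may be only part of what the source reports. "The series", "measured", "known", "first", "only" and "open" are said of these compounds alone.

Three compounds of one family have been run in an in vitro ADME assay on microsomes from liver (Homo sapiens) for metabolic stability; a lower number here means slower removal, a higher number faster removal of the compound. Compound 1 `CC(C)NC(=O)[C@H]1CC[C@@H](n2/c(=N/C(=O)c3ccc(C#N)c(F)c3)[nH]c3ccc(CN4CCC(C(C)(C)O)CC4)cc32)CC1` gives 132 mL.min-1.g-1 in this assay. Compound 2 `CC(C)NC(=O)[C@H]1CC[C@@H](n2/c(=N/C(=O)c3ccc(F)cc3)[nH]c3ccc(CN4CC(C(C)(C)O)C4)cc32)CC1` gives 105 mL.min-1.g-1 in this assay, and compound 3 `CCOC(=O)[C@H]1CC[C@@H](n2/c(=N/C(=O)c3ccccc3)[nH]c3ccc(CN4CCCCC4)cc32)CC1` gives 222 mL.min-1.g-1 in this assay. Compound 2 stands close to compound 1, the gap between the two lying within the usual scatter of repeated measurements, so no order can be read between them. Its gap to compound 3 is wider and lies beyond the scatter, so compound 3 is removed faster than compound 2 in this assay.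

Compound 4 `CC(C)NC(=O)[C@H]1CC[C@@H](n2/c(=N/C(=O)c3ccc(F)cc3)[nH]c3ccc(CN4CCNC(=O)C4)cc32)CC1` has not yet been measured. It differs from compound 2 in one place: 3-oxopiperazin-1-yl in place of 3-(1-hydroxy-1-methylethyl)azetidin-1-yl on a saturated chain carbon bound to an aromatic carbon. Among the measured compounds shown here, no measured pair in this set shows a step of this kind, so there is no direct guide to its size. Since both groups that leave and enter carry one hydrogen-bond donor and two hydrogen-bond acceptors and are of similar size, the expected step from compound 2 to compound 4 in this assay is small, a 1.1-fold lower number from compound 2 to compound 4 (0.04 log units; within the scatter), and is not expected to exceed the scatter in either direction. Compound 4 is therefore estimated at 95 mL.min-1.g-1 in this assay, within a range from 45 mL.min-1.g-1 to 190 mL.min-1.g-1.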

Compound 4, intrinsic clearance in microsomes: 194 mL.min-1.g-1
Beside the measured number, compound 4's estimate is 2.0-fold (0.31 log units) below it, and the stated range ends below it.
By their numbers in this assay, from the lowest: compounds 2, 1, 4 and 3 (each within the scatter of the next, the first and the last beyond it).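

Among the compounds shown here, this is the first step in the set that changes only the group on a saturated chain carbon bound to an aromatic carbon, with the rest of the molecule held constant. In this assay, putting 3-oxopiperazin-1-yl in place of 3-(1-hydroxy-1-methylethyl)azetidin-1-yl gives a 1.8-fold higher number from compound 2 to compound 4 (0.27 log units; within the scatter), so this exchange of a four-membered ring for a six-membered ring with a second hetero atom, at equal counts of hydrogen-bond donors and acceptors, produces no difference that can be told from repeat-measurement noise. Nothing available here accounts for the size of this step.

A single pair cannot show whether other groups at this place would move the number further, for example a morpholine ring, a plain dimethylamino group or a piperazine ring carrying a carboxylic acid. As far as these compounds go, it also remains open whether the same exchange would give a similar step with the other parts of the molecule changed, such as the benzoyl ring or the isopropyl amide.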